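The source may hold more compounds than are shown below. What is called first, only, known or untested is meant among the compounds shown, and "the series" means these compounds.

Measured compounds:
- compound 1, `CN1CCN(c2ccc3nc(-c4ccc(-c5ccccc5)s4)c(-c4ccncc4)n3n2)CC1`: > 10000 nM
- compound 2, `CN1CCN(c2ccc3nc(-c4cccc5ccccc45)c(-c4ccncc4)n3n2)CC1`: 880 nM
- compound 3, `CN1CCN(c2ccc3nc(-c4ccc(-c5ccccc5)cc4)c(-c4ccncc4)n3n2)CC1`: > 10000 nM

Three compounds share one core and differ only in the aromatic group on one carbon of that core. In an assay on Sf9 cells for inhibition of receptor-interacting serine/threonine-protein kinase 3 (Homo sapiens), read by luminescence and 33P incorporation, with a stated time of 30 min, in the presence of a further agent that is not named here (on this read-out lower numbers stand for stronger inhibition and higher numbers for weaker inhibition), compound 1 reaches only the limit of the assay, > 10000 nM, and not a number. Compound 3 likewise sits at the limit, > 10000 nM. Among the measured compounds shown here, compound 2 gives 880 nM, the only real number among the three, so it stands alone as the one measurable inhibitor here. For the measured compounds named here, the step of an at least 11-fold lower number from compound 1 to compound 2 (1.05 log units; beyond the scatter) is the one measured step, and it shows that replacing a long two-ring chain with a compact fused naphthalen-1-yl brings a large gain; compound 3 carries a comparable two-ring chain and also reaches only the limit (the limit of > 10000 nM in this assay, at which 2 of the 3 values shown sit).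

Compound 4, `CN1CCN(c2ccc3nc(-c4cccc(-c5ccsc5)c4)c(-c4ccncc4)n3n2)CC1`, still unmeasured, reverses this direction: 3-(thiophen-3-yl)phenyl in place of naphthalen-1-yl on an aromatic carbon. It returns to a two-ring chain, though the rings are joined differently from compounds 1 and 3, so the outcome is uncertain.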

Compound 4, half-maximal inhibitory concentration: 300 nM
Compound 4: the middle estimate sits 17-fold (1.22 log units) above what was measured; the measured number lies below the stated range.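

In this assay, the change to 3-(thiophen-3-yl)phenyl gives a 2.9-fold lower number from compound 2 to compound 4 (0.47 log units; beyond the scatter), so on this aromatic carbon the compact fused naphthalen-1-yl is not required, and a group made of two separate joined rings can do better. The change from 5-phenylthiophen-2-yl gives an at least 33-fold lower number from compound 1 to compound 4 (1.52 log units; beyond the scatter), so having two joined rings here does not by itself decide the outcome, and the identity of the rings and how they are joined matter among these compounds. Compound 3, which also carries two joined rings, stays at a limit of the assay: the limit of > 10000 nM in this assay, at which 2 of the 4 values shown sit.

The compounds shown leave open whether the sulfur-containing ring matters, which a plain phenyl ring in place of thiophen-3-yl would test. They also leave open whether a single chlorine atom or a methoxy group on the phenyl ring could replace the whole thiophen-3-yl ring.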